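Adding a methoxy on the other phenyl of compound 1

This account rests on a few compounds, and the source may have more. Where it says the series, first, only, none or still open, it means among the compounds named here.

Measured compounds:
compound 1 `COc1ccc(Cn2cc(CNC(=O)c3cn(-c4ccccc4)nc3-c3ccccc3)nn2)cc1` 10200 nM
compound 2 `COc1ccc(Cn2cc(CNC(=O)c3cn(-c4ccccc4)nc3-c3ccccc3)nn2)cc1OC` 8200 nM
compound 3 `COc1cc(Cn2cc(CNC(=O)c3cn(-c4ccccc4)nc3-c3ccccc3)nn2)cc(OC)c1OC` 1000 nM

Of the compounds shown here, three share one core and have been tested in a functional assay on MIA PaCa-2 cells (Homo sapiens) for antiproliferative activity, read by sulforhodamine B assay, with a stated time of 48 h; a higher number here means a weaker inhibitor of growth, a lower number a stronger inhibitor of growth. Compound 1 gives the highest number of the three; compound 2 lies nearest, and the step of a 1.2-fold lower number from compound 1 to compound 2 (0.09 log units; within the scatter) is within the scatter. Compound 3 lies furthest, and the step of a 10-fold lower number from compound 1 to compound 3 (1.01 log units; beyond the scatter) is large. The step of an 8.2-fold lower number from compound 2 to compound 3 (0.91 log units; beyond the scatter) is also beyond the scatter, so the gain in this series comes with the third methoxy on the ring bound to the saturated chain carbon.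

Compound 4 `COc1ccc(Cn2cc(CNC(=O)c3cn(-c4ccccc4)nc3-c3ccc(OC)cc3)nn2)cc1` is not yet measured. It differs from compound 1 by methoxy in place of hydrogen on an aromatic carbon. Going by the values given here, this methoxy enters a different ring from the one that carries the methoxy groups of compounds 2 and 3, so no measured step reads directly on it. The only single methoxy additions shown, a 1.2-fold lower number from compound 1 to compound 2 (0.09 log units; within the scatter) and an 8.2-fold lower number from compound 2 to compound 3 (0.91 log units; beyond the scatter), range from within the scatter to modest. Compound 4 is therefore expected to give a number close to compound 1, with the step of a 1.3-fold lower number from compound 1 to compound 4 (0.11 log units; within the scatter) likely within the scatter. The estimate for compound 4 in this assay is 8000 nM, with a range from 3000 nM to 20000 nM.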

Compound 4, concentration for 50% growth inhibition: 2500 nM
For compound 4 the middle estimate is 3.2-fold (0.51 log units) above the measured one; the whole stated range lies above it.
By their numbers in this assay, from the lowest: compound 3; then compound 4; then compounds 2 and 1 (each within the scatter of the next).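

In this assay, the phenyl of the shared core turns out to be a place where substitution counts: phenyl to 4-methoxyphenyl, with the methoxy para to a large group, gives a 4.1-fold lower number from compound 1 to compound 4 (0.61 log units; beyond the scatter). The earlier compounds shown here showed a step beyond the scatter only on the ring bound to the saturated chain carbon, and only for the third methoxy there, whereas here a single methoxy on an otherwise unsubstituted ring is enough. Set beside that earlier gain, the new step cannot be told apart from it in size: the same change on two cores in this assay, an 8.2-fold lower number (0.91 log units; beyond the scatter) from compound 2 to compound 3 and a 4.1-fold lower number (0.61 log units; beyond the scatter) from compound 1 to compound 4, 2.0-fold (0.30 log units) apart, within the scatter of two such steps.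

From the compounds shown here alone, whether a hydroxyl, a chlorine or an amine in this place would give a similar step stays open. So does whether this methoxy and the 3,4,5-trimethoxyphenyl group of compound 3 would add up in a single compound.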